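The source may hold more compounds than are shown below. What is called first, only, known or untested is meant among the compounds shown, and "the series" means these compounds.

In a functional assay on SiHa cells (Homo sapiens) for inhibition (on this read-out lower numbers stand for stronger inhibition and higher numbers for weaker inhibition), three compounds built on one shared core have been measured. Compound 1 `COc1cc(/C=C/C(=O)c2cccc(NC(=O)c3c(Cl)cccc3Cl)c2)ccc1O` gives 3.56 ug/mL, compound 2 `COc1cc(/C=C/C(=O)c2cccc(N)c2)ccc1O` gives 12.3 ug/mL, and compound 3 `COc1cc(/C=C/C(=O)c2cccc(NC(=O)C(C)C)c2)ccc1O` gives 5.96 ug/mL. Two steps place compound 3 among them. It cannot be told apart from its dichlorinated partner, as the step is a 1.7-fold higher number from compound 1 to compound 3 (0.22 log units; within the scatter), but it does stand apart from the amine, with a 2.1-fold lower number from compound 2 to compound 3 (0.31 log units; beyond the scatter). The widest step seen is a 3.5-fold higher number from compound 1 to compound 2 (0.54 log units; beyond the scatter).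

Compound 4 `COc1cc(/C=C/C(=O)c2cccc(NC(=O)c3ccccc3)c2)ccc1O` differs from compound 3 by one change: phenyl in place of isopropyl on a carbonyl carbon. In words, this is phenyl in place of isopropyl on a carbonyl carbon. The closest evidence is the swap of isopropyl for 2,6-dichlorophenyl at that same carbonyl carbon, which stayed within the scatter. Going by the values given here, no measured compound carries the unsubstituted phenyl, so that evidence is indirect. No change beyond the scatter is therefore expected in this assay, and the expected step is a 1.3-fold lower number from compound 3 to compound 4 (0.11 log units; within the scatter). Compound 4 is estimated at 4.6 ug/mL, with an expected range from 2.3 ug/mL to 9.2 ug/mL.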

Compound 4, half-maximal inhibitory concentration: 4.57 ug/mL
Compound 4: the middle estimate sits 1.0-fold (0.00 log units) above what was measured; measured number inside the range.
By their numbers in this assay, from the lowest: compounds 1, 4 and 3 (each within the scatter of the next); then compound 2.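

In this assay, the unsubstituted phenyl on the carbonyl carbon cannot be told apart from either earlier amide: replacing isopropyl gives a 1.3-fold lower number from compound 3 to compound 4 (0.12 log units; within the scatter), and replacing 2,6-dichlorophenyl gives a 1.3-fold higher number from compound 1 to compound 4 (0.11 log units; within the scatter). The benzamido compound does stand apart from the free amine, with a 2.7-fold lower number from compound 2 to compound 4 (0.43 log units; beyond the scatter), so all three amides shown now differ from that amine beyond the scatter, and none goes against this. No measurement offered here explains these results.

The compounds shown leave open whether a smaller acyl group such as acetyl, or a longer chain such as hexanoyl, would stay within the scatter of these amides. They also leave open whether a benzoyl group carrying a single chlorine or a methoxy group would do so.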